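The source may report more compounds than this note shows. Statements on the series, on what has been measured and on what is new or still open speak of the compounds shown alone.

Of the compounds shown here, three built on one shared core have been tested in a functional assay on HCT-116 cells (Homo sapiens) for cytotoxicity, read by MTT assay, with a stated time of 72 h; a higher number here means a weaker inhibitor, a lower number a stronger inhibitor. Compound 1 `O=C(NCc1ccc(F)cc1)c1nc(Br)c2cccnc2c1NCc1ccccc1` carries a benzylamino group on an aromatic carbon of the core; in this assay compound 1 gives > 20000 nM, which is a limit of the assay rather than a number. Compound 2 `O=C(NCc1ccc(F)cc1)c1nc(Br)c2cccnc2c1N1CCNCC1` has piperazin-1-yl in that place, and in this assay compound 2 gives > 10000 nM, again a limit. Compound 3 `Cc1ccc(S(=O)(=O)Oc2c(C(=O)NCc3ccc(F)cc3)nc(Br)c3cccnc23)cc1` carries ((4-methylphenyl)sulfonyl)oxy there, and in this assay compound 3 gives > 20000 nM, also a limit. Compound 3 thus stands at the limit of > 20000 nM in this assay, at which 2 of the 3 values shown sit, together with compound 1, while compound 2 sits at the limit of > 10000 nM in this assay, at which 1 of the 3 values shown sits. With every value a limit, none of the steps among them can be read: a step that the two limits leave unreadable from compound 1 to compound 2, a step that the two limits leave unreadable from compound 1 to compound 3 and a step that the two limits leave unreadable from compound 2 to compound 3.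

Compound 4 `NCCCCCCNc1c(C(=O)NCc2ccc(F)cc2)nc(Br)c2cccnc12` is not yet measured. It differs from compound 3 by (6-aminohexyl)amino in place of ((4-methylphenyl)sulfonyl)oxy on an aromatic carbon. For the measured compounds named here, no measured step bears readably on this change, so neither size nor direction can be drawn from the steps; what remains is that all three relatives reached a limit. Compound 4 is therefore expected to give about 20000 nM, within a range from 3000 nM to 60000 nM, and the expected step is a number no higher from compound 3 to compound 4 (the limit leaves the size open).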

Compound 4, half-maximal inhibitory concentration: 7000 nM
Compound 4: the middle estimate sits 2.9-fold (0.46 log units) above what was measured; the range from low to high includes it.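

For the compounds shown here, at this position, para to the bromo group, (6-aminohexyl)amino gives the first true number on this core in this assay, whereas compound 1 and compound 3 stop at a limit: the limit of > 20000 nM in this assay, at which 2 of the 4 values shown sit. Putting this chain in place of the ((4-methylphenyl)sulfonyl)oxy group gives an at least 2.8-fold lower number from compound 3 to compound 4 (0.45 log units; beyond the scatter), and putting it in place of benzylamino gives an at least 2.8-fold lower number from compound 1 to compound 4 (0.45 log units; beyond the scatter). Against piperazin-1-yl the result is an at least 1.4-fold lower number from compound 2 to compound 4 (0.15 log units; that floor lies within the scatter), so this comparison shows no firm gain.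

The steps among compound 1, compound 2 and compound 3 cannot be read, and the compounds shown do not separate the part played by the chain length from that of the amine at its end. A shorter (2-aminoethyl)amino chain, or a plain hexylamino chain with no end amine, would address that question.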